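A Nitro Group Tried on a Second Core

The source may report more compounds than this note shows. Statements on the series, on what has been measured and on what is new or still open speak of the compounds shown alone.

Compound 1 `CC1(C)OC(C)(C)c2c1nnc(-c1ccccc1)[n+]2[O-]` and compound 2 `CC1(C)OC(C)(C)c2c1nnc(-c1cccc([N+](=O)[O-])c1)[n+]2[O-]` share one core and differ in a single place: nitro in place of hydrogen on an aromatic carbon. In a functional assay on the whole organism with Mus musculus as the target (a lower number here means that less compound is needed, a higher number that more compound is needed for the effect), compound 1 gives 163 mg/kg and compound 2 gives 72 mg/kg, so this change brought a 2.3-fold lower number from compound 1 to compound 2 (0.35 log units; beyond the scatter). Compound 3 `CC1(C)Cc2nnc(-c3ccccc3)[n+]([O-])c2C(C)(C)O1` carries a different core; how the two cores differ is not broken down here. In this assay compound 3 gives 122 mg/kg, which lies within the usual scatter of the number for compound 1. Compound 4 `CC1(C)Cc2nnc(-c3cccc([N+](=O)[O-])c3)[n+]([O-])c2C(C)(C)O1` is compound 3 with the same change applied: nitro in place of hydrogen on an aromatic carbon. Because the same change once gave a 2.3-fold lower number from compound 1 to compound 2 (0.35 log units; beyond the scatter), a step of similar size is expected here, a 2.3-fold lower number from compound 3 to compound 4 (0.36 log units; beyond the scatter). Compound 4 is therefore estimated to give 53 mg/kg in this assay, most likely between 30 mg/kg and 100 mg/kg.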

Compound 4, dose for half-maximal effect: 500 mg/kg
Compound 4: middle estimate off by 9.4-fold (0.97 log units), on the low side; measured number outside the range, above it.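

In this assay, putting the nitro group on compound 3 brought a 4.1-fold higher number from compound 3 to compound 4 (0.61 log units; beyond the scatter), so the change did not carry over from one core to the other. The two steps run in opposite directions, and the step on one core did not predict the step on the other: the same change on two cores in this assay, a 2.3-fold lower number (0.35 log units; beyond the scatter) from compound 1 to compound 2 and a 4.1-fold higher number (0.61 log units; beyond the scatter) from compound 3 to compound 4, 9.3-fold (0.97 log units) apart, beyond the scatter of two such steps. For the compounds shown here, with only two pairs, this does not show which feature of the two cores goes with the difference, or what the same change would do on a third core.

The compounds shown leave open whether another group in the nitro group's place, such as an amine or a carboxylic acid, would also behave differently on the two cores.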